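Swapping the anilide aryl group and its effect on clearance

A few compounds are considered here, and "the series" means these few. Any claim that something is new, unique, unknown or untested is made for them only; others in the source may bear on it.

Compound 1 `CN1C[C@H](C(=O)Nc2ccc(Br)cc2)[C@@H](c2ccc(/C=C/C(=O)Nc3ccccc3N)cc2)C1` is the anchor here. In an in vitro ADME assay on microsomes from liver (Homo sapiens) for pharmacokinetics, read by LC-MS, with a stated time of 10 min, tested at 1 uM (a higher number here means faster removal of the compound, a lower number slower removal), compound 1 gives 3 mL/min/kg, the lowest of the three numbers measured. Compound 2 `CN1C[C@H](C(=O)Nc2ccccc2F)[C@@H](c2ccc(/C=C/C(=O)Nc3ccccc3N)cc2)C1` gives 10 mL/min/kg in this assay, and compound 3 `CN1C[C@H](C(=O)Nc2ccc(F)c(Br)c2)[C@@H](c2ccc(/C=C/C(=O)Nc3ccccc3N)cc2)C1` gives 15 mL/min/kg. Both of its neighbours therefore sit higher: a 3.3-fold higher number from compound 1 to compound 2 (0.52 log units; beyond the scatter) and a 5.0-fold higher number from compound 1 to compound 3 (0.70 log units; beyond the scatter), while a 1.5-fold higher number from compound 2 to compound 3 (0.18 log units; within the scatter) separates the two higher compounds.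

Compound 4 `CN1C[C@H](C(=O)Nc2ccc(Cl)cc2F)[C@@H](c2ccc(/C=C/C(=O)Nc3ccccc3N)cc2)C1` has not yet been measured. It differs from compound 1 in one place (4-chloro-2-fluorophenyl in place of 4-bromophenyl on an amide-type nitrogen). The two steps that bear on it are the same kind of exchange, a different aryl group on the amide-type nitrogen, and both moved the number upward by a modest, beyond-scatter margin. The expectation is that compound 4 follows the same direction, landing in the region occupied by compound 2 and compound 3 rather than with compound 1. Compound 4 is therefore expected to give about 10 mL/min/kg, with a plausible range from 4 mL/min/kg to 25 mL/min/kg. That estimate corresponds to an expected step of a 3.3-fold higher number from compound 1 to compound 4 (0.52 log units; beyond the scatter).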

Compound 4, clearance: 11 mL/min/kg
Beside the measured number, compound 4's estimate is 1.1-fold (0.04 log units) below it; low and high end bracket the measured number.
By their numbers in this assay, from the lowest: compound 1; then compounds 2, 4 and 3 (each within the scatter of the next).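

In this assay, the exchange to 4-chloro-2-fluorophenyl on the amide-type nitrogen gives a 3.7-fold higher number from compound 1 to compound 4 (0.56 log units; beyond the scatter) and so becomes the third aryl group at this position that does not share the number of 4-bromophenyl. Chloro in place of hydrogen on an aromatic carbon cannot be told apart from hydrogen here, with a 1.1-fold higher number from compound 2 to compound 4 (0.04 log units; within the scatter) inside the scatter, and a 1.4-fold lower number from compound 3 to compound 4 (0.13 log units; within the scatter) also stands within it, so compounds 2, 3 and 4 form one cluster apart from compound 1. No measurement shown here explains why compound 1 stands apart.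

On these data alone, it remains open whether 4-chlorophenyl or 4-bromo-2-fluorophenyl on this nitrogen would stand with compound 1 or with the cluster. As far as these compounds go, how a pyridyl ring or a 4-methoxyphenyl group would fare at this position is also open.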